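The compounds below may be only part of what the source reports. "The series", "measured", "known", "first", "only" and "open" are said of these compounds alone.

In a functional assay on cells (Melanoma cell, Homo sapiens) for cytotoxicity, read by sulforhodamine B assay, with a stated time of 48 h (on this read-out lower numbers stand for stronger inhibition of growth and higher numbers for weaker inhibition of growth), compound 1 `COc1ccc(OC)c(-c2cc(-c3ccccc3)nn2-c2ccc(S(N)(=O)=O)cc2)c1` gives 15300 nM. Compound 2 `COc1ccc(OC)c(-c2cc(-c3ccccc3)nn2-c2ccc(S(=O)(=O)NC(C)=O)cc2)c1` gives 15400 nM in this assay, and the step of a 1.0-fold higher number from compound 1 to compound 2 (0.00 log units; within the scatter) shows that acetyl in place of hydrogen on the sulfonamide nitrogen left the result essentially unchanged, so compound 2 sits alongside compound 1 within the scatter. Compound 3 `CC(=O)NS(=O)(=O)c1ccc(-n2nc(-c3ccccc3)cc2C2=CC(=O)C=CC2=O)cc1` differs from compound 2 by a group of 8 heavy atoms (6 carbon, 2 oxygen; one six-membered non-aromatic ring of carbon only) in place of a group of 10 heavy atoms (8 carbon, 2 oxygen; one six-membered aromatic ring of carbon only), on an aromatic carbon. Within the data shown here, no measured step touches that position; the only known step concerns the sulfonamide nitrogen and was flat, so it offers no guide to direction. Compound 3 is therefore expected to give about 10000 nM, with a range from 2000 nM to 40000 nM, an expected step of a 1.5-fold lower number from compound 2 to compound 3 (0.19 log units; within the scatter).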

Compound 3, concentration for 50% growth inhibition: 92000 nM
For compound 3 the middle estimate is 9.2-fold (0.96 log units) below the measured one; measured number above the stated range.
By their numbers in this assay, from the lowest: compounds 1 and 2 (each within the scatter of the next); then compound 3.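

Unlike the sulfonamide nitrogen, where the earlier step was flat, this position on the five-membered aromatic ring responds to change in this assay: putting the non-aromatic six-membered carbon ring with its two oxygens in place of 2,5-dimethoxyphenyl gives a 6.0-fold higher number from compound 2 to compound 3 (0.78 log units; beyond the scatter) and thus weaker growth inhibition. Nothing available explains this loss. With a single replacement shown at this position, it remains open which feature of the entering or leaving group matters, and how an amine or a carboxylic acid there would compare.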